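From 3-hydroxyphenyl to 2-methylphenyl: compound 4 awaits measurement

The source may hold more compounds than are shown below. What is called first, only, known or untested is meant among the compounds shown, and "the series" means these compounds.

Compound 1 `CC1(C)[C@H]2CC[C@]1(C)N(Cc1cn(-c3cccc(F)c3)nn1)C(=O)C2` gives 530 nM
Compound 2 `CC1(C)[C@H]2CC[C@]1(C)N(Cc1cn(-c3ccccc3Br)nn1)C(=O)C2` gives 500 nM
Compound 3 `CC1(C)[C@H]2CC[C@]1(C)N(Cc1cn(-c3cccc(O)c3)nn1)C(=O)C2` gives 270 nM

All three values come from a functional assay on SGC-7901 cells (Homo sapiens) for inhibition, read by MTT assay, with a stated time of 24 h (on this read-out lower numbers stand for stronger inhibition and higher numbers for weaker inhibition), and the three compounds share one core. Compound 3 does not stand apart from the other two on these numbers. The steps that reach it are a 2.0-fold lower number from compound 1 to compound 3 (0.29 log units; within the scatter) and a 1.9-fold lower number from compound 2 to compound 3 (0.27 log units; within the scatter) and both stay within the scatter, as does a 1.1-fold lower number from compound 1 to compound 2 (0.03 log units; within the scatter) between the other two.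

Compound 4 `Cc1ccccc1-n1cc(CN2C(=O)C[C@@H]3CC[C@@]2(C)C3(C)C)nn1` keeps the same core and brings one change from compound 3, with 2-methylphenyl in place of 3-hydroxyphenyl on an aromatic nitrogen. Within the data shown here, no measured compound carries this group. The closest comparison is compound 2, with its 2-bromophenyl, and compound 2 gives 500 nM in this assay. All three measured exchanges of this group stayed within the scatter, so no step beyond the scatter is expected, only a possible small drift towards the number of compound 2. The expected size is a 1.6-fold higher number from compound 3 to compound 4 (0.20 log units; within the scatter), an estimate that remains within the scatter. For compound 4 the estimated value is 430 nM, with an expected range from 200 nM to 900 nM.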

Compound 4, half-maximal inhibitory concentration: 350 nM
Compound 4: the middle estimate sits 1.2-fold (0.09 log units) above what was measured; the range from low to high includes it.
By their numbers in this assay, from the lowest: compounds 3, 4, 2 and 1 (each within the scatter of the next).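

In this assay, the exchange on the aromatic nitrogen, a 1.3-fold higher number from compound 3 to compound 4 (0.11 log units; within the scatter), removes the hydrogen-bond donor and acceptor counted on 3-hydroxyphenyl, and 2-methylphenyl, which has neither, still gives a number that cannot be told apart from that of compound 3, so a hydroxy group is not needed on this aryl ring to stay within this range. Among these compounds, the other two new comparisons agree: methyl in place of bromo gives a 1.4-fold lower number from compound 2 to compound 4 (0.15 log units; within the scatter), and 2-methylphenyl in place of 3-fluorophenyl gives a 1.5-fold lower number from compound 1 to compound 4 (0.18 log units; within the scatter), so a substituent of carbon alone now joins fluoro, bromo and hydroxy, and no step among the four compounds leaves the scatter. Nothing at hand accounts for this flat picture.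

What the compounds shown leave open is whether this position can produce a real difference at all, for instance with an amine or a carboxylic acid on the phenyl ring, or with a longer alkyl chain in place of that ring. They also cannot say whether the same flat picture would hold if the shared core were changed, since all four compounds keep it.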